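Swapping ethoxycarbonyl for butylsulfonyl on a shared core

The source may hold more compounds than are shown below. What is called first, only, known or untested is meant among the compounds shown, and "the series" means these compounds.

Measured so far:
compound 1 `CCOC(=O)c1sc2nc(-c3cccs3)cc(-c3ccccc3)c2c1N` — > 7500 nM
compound 2 `CCCC[S+]([O-])c1sc2nc(-c3nccn3C)nc(-c3ccccc3)c2c1N` — 3.7 nM

In an assay for inhibition of 15-hydroxyprostaglandin dehydrogenase [NAD(+)] (Homo sapiens), read by fluorescence, with a stated time of 15 min, in the presence of a further agent that is not named here (a lower number here means a stronger inhibitor, a higher number a weaker inhibitor), compound 1 returns only a limit, > 7500 nM; this is a limit of the assay and not a number, as noted in the limit of > 7500 nM in this assay, at which 1 of the 2 values shown sits. Compound 2 gives 3.7 nM in this assay. Compound 2 differs from compound 1 in several places at once, so no single step can be read between the two; their values show only that one sits at the limit while the other is a strong inhibitor. Among the measured compounds shown here, no step between compounds that differ in one place has been measured.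

Compound 3 `CCCCS(=O)(=O)c1sc2nc(-c3cccs3)cc(-c3ccccc3)c2c1N` remains to be measured in this assay. It keeps the core of compound 1 and changes one group: butylsulfonyl in place of ethoxycarbonyl on an aromatic carbon.

Given that compound 1 sits at the limit > 7500 nM, the step is expected to run toward stronger inhibition, well beyond the usual scatter, as an at least 120-fold lower number from compound 1 to compound 3 (2.09 log units; beyond the scatter). Compound 3 is estimated at 60 nM, within 8 nM to 600 nM, though a result that again ends at a limit cannot be ruled out.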

Compound 3, half-maximal inhibitory concentration: 25 nM
Compound 3: the middle estimate sits 2.4-fold (0.38 log units) above what was measured, within the range that was stated.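

With the shared core held fixed, the change of butylsulfonyl in place of ethoxycarbonyl on this aromatic carbon, next to the ring sulfur, can now be read as a single step in this assay, and it gives an at least 300-fold lower number from compound 1 to compound 3 (2.47 log units; beyond the scatter). The earlier pair differed in several places at once and could not tie strong inhibition to any one group, whereas this step shows that the group at this position alone is enough to carry a compound from the limit of the assay to strong inhibition. The true size of the step stays unknown and the printed size is only a floor, because compound 1 stands at a limit and not at a number: the limit of > 7500 nM in this assay, at which 1 of the 3 values shown sits.

As far as these compounds go, whether the step belongs to the sulfonyl unit or to the butyl chain stays open, and methylsulfonyl, a longer chain on the sulfonyl, a primary amide or a carboxylic acid on the same carbon would separate the two. Also open, from the compounds shown here alone, is whether the same change carries the same weight on other cores, since compound 2 and compound 3 differ in more than one place and no single step can be read between them.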